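Trimming the ester arm of compound 1 to a methyl

The source may hold more compounds than are shown below. What is called first, only, known or untested is meant among the compounds shown, and "the series" means these compounds.

Measured so far in an assay on VSM-A10 cells for antagonist activity at Endothelin-1 receptor (Rattus norvegicus); a lower number here means a stronger inhibitor, a higher number a weaker inhibitor:
compound 1 `CCOC(=O)C(C)Nc1cccc2c(S(=O)(=O)Nc3onc(C)c3C)cccc12`: 400 nM
compound 2 `Cc1noc(NS(=O)(=O)c2cccc3c(N(C)C)cccc23)c1Cc1ccccc1`: 50000 nM
compound 3 `Nc1ccc(S(=O)(=O)Nc2noc3c2CCCC3)cc1`: > 32000 nM

Compound 1 has the lowest number of the two that were measured as numbers. Compound 2 differs from it in more than one place and gives a much higher number, beyond the usual scatter, so no single cause can be read from that pair. For compound 3 this assay reports only a limit, not a number; it sits at the limit of > 32000 nM in this assay, at which 1 of the 3 values shown sits.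

Compound 4 `CNc1cccc2c(S(=O)(=O)Nc3onc(C)c3C)cccc12` keeps the core of compound 1 and changes one group: methyl in place of 1-(ethoxycarbonyl)ethyl on a nitrogen on an aromatic ring. Among the compounds with values here, no pair of measured compounds shows this step on its own, so its size is a guess. The ester arm that leaves is large and the group that enters is small; compound 2, which also lacks the ester arm, gives 50000 nM, a far weaker result than compound 1, though it differs elsewhere too. A weakening step is expected, a 7.5-fold higher number from compound 1 to compound 4 (0.88 log units; beyond the scatter), clearly beyond the scatter. Compound 4 is therefore estimated at 3000 nM, with a likely range from 600 nM to 15000 nM.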

Compound 4, half-maximal inhibitory concentration: 130 nM
Compound 4: middle estimate off by 23-fold (1.36 log units), on the high side, and the stated range ends above it.
By their numbers in this assay, from the lowest: compound 4; then compound 1; then compound 2.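

Replacing the ester arm with a methyl on this nitrogen gives a 3.1-fold lower number from compound 1 to compound 4 (0.49 log units; beyond the scatter) in this assay and so a modest gain rather than a loss. Within the data shown here, the large 1-(ethoxycarbonyl)ethyl group is therefore not needed for inhibition in this pair, and a single methyl does better; the earlier compounds could not show this, as none of them differed from compound 1 at this nitrogen alone. Nothing measured here accounts for the gain.

One step does not show whether smaller is simply better at this position or whether methyl is a special case. The plain amine, an ethyl or longer chain, and a carboxylic acid in place of the ester would each be needed to tell how far this nitrogen accepts change.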